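The compounds below may be only part of what the source reports. "The series", "measured", "known", "first", "only" and "open" are said of these compounds alone.

Three amides built on one shared core have been measured in an assay on NIH3T3 cells with Urotensin-2 receptor (Homo sapiens) as the target; on this read-out lower numbers stand for smaller maximal responses and higher numbers for larger maximal responses. Compound 1 `Cc1ccccc1C(=O)NC(CCN(C)C)c1ccc(Cl)cc1` gives 175% in this assay. Compound 2 `COc1ccc(C(=O)NC(CCN(C)C)c2ccc(Cl)cc2)cc1` gives 162%, and compound 3 `Cc1ccc(C)c(C(=O)NC(CCN(C)C)c2ccc(Cl)cc2)c1` gives 164%. Among these three numbers compound 3 stands second highest: its nearest neighbour is compound 2, whose value lies within the scatter of its own, while the step of a number 11 percentage points lower from compound 1 to compound 3 (beyond the scatter) separates it from compound 1 beyond the scatter.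

Compound 4 `Cc1cc(C)c(C(=O)NC(CCN(C)C)c2ccc(Cl)cc2)cc1C` has not yet been measured. It differs from compound 3 in a single place: methyl in place of hydrogen on an aromatic carbon.

The measured step that bears most directly on this change is a number 11 percentage points lower from compound 1 to compound 3 (beyond the scatter), where a methyl likewise replaced a hydrogen on an aromatic carbon and the maximal response fell modestly. The comparison a number 2 percentage points higher from compound 2 to compound 3 (within the scatter), in which a 2,5-dimethylphenyl stood in place of a 4-methoxyphenyl on the carbonyl carbon, stayed within the scatter. A further methyl is therefore expected to lower the response only a little, if at all, and the step of a number 8 percentage points lower from compound 3 to compound 4 (within the scatter) is expected to remain near the edge of the scatter. For compound 4 a value of 156% is expected, within a range from 138% to 174%.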

Compound 4, largest response reached (reported as efficacy), in percent of the reference or control that the assay uses: 159%
Estimate against measurement, compound 4: 3 percentage points below; the measured number falls inside the stated range.
By their numbers in this assay, from the lowest: compounds 4, 2 and 3 (each within the scatter of the next); then compound 1.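

In this assay, a number 5 percentage points lower from compound 3 to compound 4 (within the scatter), so a methyl on this ring carbon, para to a large group and already flanked by the two existing methyl groups in the words of its ortho and meta relations, leaves the maximal response unchanged within the usual spread of repeat measurements. Among these compounds, this differs from the only earlier methyl-for-hydrogen step on this ring, a number 11 percentage points lower from compound 1 to compound 3 (beyond the scatter), which lies beyond the scatter, so adding a methyl to this ring does not always shift the read-out measurably, and this ring carbon tolerates the extra carbon with no readable change. Nothing available explains why one methyl step lies beyond the scatter and the other within it.

On these data alone, this position rests on a single pair of compounds, so it remains open whether a methyl here would behave the same on a ring lacking the other two methyl groups. As far as these compounds go, it also remains open whether a larger or different group at this ring carbon, such as an ethyl chain, an amine or a carboxylic acid, would leave the response as undisturbed as methyl does.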